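The compounds below may be only part of what the source reports. "The series", "measured", "known", "first", "only" and "open" are said of these compounds alone.

Measured so far:
- compound 1, `CC1CCCC(C(=O)N2CC(c3nc(-c4cccc(Cl)c4)no3)C2)C1`: > 10000 nM
- compound 2, `Cc1cccc(S(=O)(=O)N2CC(c3nc(-c4cccc(Cl)c4)no3)C2)c1`: 390 nM
- compound 3, `Cc1cccc(-c2noc(C3CN(S(=O)(=O)c4ccc(Cl)cc4)C3)n2)c1`: 1100 nM

In an assay on HEK293 cells for negative allosteric modulation of metabotropic glutamate receptor 5 (Homo sapiens), read by FLIPR (on this read-out lower numbers stand for stronger inhibition and higher numbers for weaker inhibition), compound 1 gives > 10000 nM, which is a limit of the assay and not a number. Compound 1 therefore sits at the limit of > 10000 nM in this assay, at which 1 of the 3 values shown sits, with no number of its own. Among the measured compounds only compound 2 and compound 3 return numbers, and no step between them and compound 1 has been worked out, so for compound 1 nothing more than the limit can be said.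

Compound 4, `CC1CN(C(=O)N2CC(c3nc(-c4cccc(Cl)c4)no3)C2)CC(C)O1`, has not been measured in this assay. It differs from compound 1 by 2,6-dimethylmorpholin-4-yl in place of 3-methylcyclohexyl on a carbonyl carbon. The carbonyl-linked part of the shared core is kept, and the cyclohexyl ring is traded for a saturated ring with two hetero atoms, as counted above. For the measured compounds named here, no measured step covers a change of this kind, so the expectation rests on compound 1 alone, and a step from its limit cannot be sized in either direction; the expectation is that compound 4 stays near the same limit, a number no higher from compound 1 to compound 4 (the limit leaves the size open).

For compound 4 in this assay the estimate is 10000 nM, within 2500 nM to 40000 nM.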

Compound 4, half-maximal inhibitory concentration: 990 nM
Beside the measured number, compound 4's estimate is 10-fold (1.00 log units) above it; the whole stated range lies above it.
By their numbers in this assay, from the lowest: compound 2; then compounds 4 and 3 (each within the scatter of the next). At a limit, above all of these: compound 1.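

In this assay, the place on the carbonyl carbon proves able to move the read-out: 2,6-dimethylmorpholin-4-yl in place of 3-methylcyclohexyl gives an at least 10-fold lower number from compound 1 to compound 4 (1.00 log units; beyond the scatter). Compound 1 gives > 10000 nM, a limit of the assay and not a number, so the step is a lower bound only, with its full size unknown: the limit of > 10000 nM in this assay, at which 1 of the 4 values shown sits. On this shared core, then, a carbonyl-linked compound is not tied to the limit, and in this one pair the group on the carbonyl carbon alone separates a limit from a number, with the entering ring carrying 2 hetero atoms and 1 hydrogen-bond acceptor where the leaving ring carries none.

This single pair does not tell whether the ring oxygen, the ring nitrogen or the two methyl groups carry the step. On these data alone, how plain morpholin-4-yl, piperidin-1-yl or piperazin-1-yl would read on the same carbonyl carbon stays open, as does the reading for an open-chain amine there.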